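The source may hold more compounds than are shown below. What is called first, only, known or untested is meant among the compounds shown, and "the series" means these compounds.

Measured so far:
compound 1 `COc1cc(/C=C/C(=O)Nc2cc3c(Nc4ccc(F)c(Cl)c4)ncnc3cc2O[C@H]2CCOC2)cc(OC)c1O`, 27000 nM
compound 2 `O=C(/C=C/c1cccc(Cl)c1Cl)Nc1cc2c(Nc3ccc(F)c(Cl)c3)ncnc2cc1O[C@H]1CCOC1`, 23200 nM
compound 3 `COc1cc2ncnc(Nc3ccc(F)c(Cl)c3)c2cc1NC(=O)/C=C/c1ccc(C#N)cc1`, "not active" (no number reported)

In a functional assay on A549 cells (Homo sapiens) for cytotoxicity, read by MTT assay, with a stated time of 72 h (a lower number here means a stronger inhibitor, a higher number a weaker inhibitor), compound 2 gives 23200 nM, the lowest of the two numbers reported, with compound 1 nearest at 27000 nM; the step of a 1.2-fold lower number from compound 1 to compound 2 (0.07 log units; within the scatter) lies within the scatter, so the two cannot be ordered. Compound 3 in this assay is reported as "not active" (no number reported), without a number.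

Compound 4 `N#Cc1ccc(/C=C/C(=O)Nc2cc3c(Nc4ccc(F)c(Cl)c4)ncnc3cc2O[C@H]2CCOC2)cc1` differs from compound 2 by 4-cyanophenyl in place of 2,3-dichlorophenyl on a double-bonded chain carbon bound to a double-bonded chain carbon. Among the measured compounds shown here, only one measured step changes this same group, the one from compound 1 to compound 2, and it was within the scatter, which suggests that swapping the aryl group on the chain does little. Compound 3, however, carries the same 4-cyanophenyl group on a different core and is reported as not active, which points the other way. Compound 4 is therefore expected to be no stronger than compound 2, and a step of a 1.9-fold higher number from compound 2 to compound 4 (0.29 log units; within the scatter) toward a weaker inhibitor is estimated. In this assay compound 4 is expected to give about 45000 nM, with a range from 15000 nM to 150000 nM, and there is a fair chance that only a limit is reported.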

Compound 4, half-maximal inhibitory concentration: "not active" (no number reported)
No number was reported for compound 4, so the estimate cannot be set against anything.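

Among the compounds shown here, compound 4 is reported in this assay as "not active", without a number, so no step from compound 2 to compound 4 can be read. The compounds shown leave open how far compound 4 lies from compound 2. Nothing given here bears on this result.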